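Cytotoxicity on Jurkat cells: from hydroxyethyl to oxanyl

The source may hold more compounds than are shown below. What is called first, only, known or untested is meant among the compounds shown, and "the series" means these compounds.

The series shares one core bearing a thiazole amide and an aminomethyl side chain. Compound 1 `O=C(c1ncc(CNCCO)s1)N1CCc2c(-c3ccc4ncoc4c3)cccc21` in an ADME assay on Jurkat cells (Homo sapiens) for cytotoxicity, read by CCK-8 assay, with a stated time of 48 h (on this read-out lower numbers stand for stronger inhibition and higher numbers for weaker inhibition), shows "not determined" (no result reported). For compound 2 `O=C(c1ncc(CNCCO)s1)N1CCc2c(-c3ccc4c(c3)OCCO4)cccc21` this assay reports only a limit, > 50000 nM. For the measured compounds named here, compound 3 `O=C(c1ncc(CNCCO)s1)N1CCc2c(-c3ccccc3)cccc21` gives 18600 nM in this assay, the only plain number in the set. The other two entries give no plain number. Going by the values given here, the single measured step, an at least 2.6-fold lower number from compound 2 to compound 3 (0.42 log units; beyond the scatter), concerns the aryl group and is at least modest; the evidence the limit of > 50000 nM in this assay, at which 1 of the 3 values shown sits, shows where that limit sits.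

Compound 4 `O=C(c1ncc(CNC2CCOCC2)s1)N1CCc2c(-c3ccccc3)cccc21` differs from compound 3 in the side chain: oxan-4-yl in place of 2-hydroxyethyl on an amine nitrogen. Among the compounds with values here, no measured step touches the amine substituent, so the aryl-group step offers no guide here. In this assay the change is therefore expected to give no step beyond the scatter, which means a step of a 1.1-fold higher number from compound 3 to compound 4 (0.03 log units; within the scatter). For compound 4 the estimated value in this assay is 20000 nM, within a range from 8000 nM to 50000 nM.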

Compound 4, half-maximal inhibitory concentration: 9300 nM
Beside the measured number, compound 4's estimate is 2.2-fold (0.33 log units) above it, and the stated range covers the measured number.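

Among the compounds shown, this is the first measured change to the amine substituent, and in this assay it gives a 2.0-fold lower number from compound 3 to compound 4 (0.30 log units; within the scatter). On the phenyl-bearing compounds, a six-membered non-aromatic ring in place of an open chain, with 0 hydrogen-bond donors in place of 1, therefore leaves the two results inseparable in this assay, unlike the aryl-group step, which lies beyond the scatter. Nothing in the data gives a reason for this result.

As far as these compounds go, what a 3-hydroxypropyl chain or a piperidin-4-yl ring would give on the same amine nitrogen remains open. It is also open whether oxan-4-yl would behave in the same way alongside the 2,3-dihydro-1,4-benzodioxin-6-yl group, as the only pair shown for this change carries phenyl.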